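A few compounds are considered here, and "the series" means these few. Any claim that something is new, unique, unknown or untested is made for them only; others in the source may bear on it.

Compound 1 `CCNC(=O)/C=C/c1c(/C=C/c2ccc(OC)cc2)cc(OC)cc1OC` gives 6990 nM in a functional assay on B16-F10 cells (Mus musculus) for inhibition, read by MTT assay, with a stated time of 48 h; a lower number here means a stronger inhibitor, a higher number a weaker inhibitor.
Compound 2 `C#CCNC(=O)/C=C/c1c(/C=C/c2ccc(OC)cc2)cc(OC)cc1OC` gives 8280 nM.
Compound 3 `COc1ccc(/C=C/c2cc(OC)cc(OC)c2/C=C/C(=O)Nc2cc(OC)c(OC)c(OC)c2)cc1` gives 8150 nM.

All three share one core and differ only in the group on the amide-type nitrogen. Compound 1 carries an ethyl there, and its number stands no farther from the other two than the scatter allows: the step of a 1.2-fold higher number from compound 1 to compound 2 (0.07 log units; within the scatter) and the step of a 1.2-fold higher number from compound 1 to compound 3 (0.07 log units; within the scatter) are both small, and compound 2 and compound 3 are likewise close to each other, a 1.0-fold lower number from compound 2 to compound 3 (0.01 log units; within the scatter).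

Compound 4 `COc1ccc(/C=C/c2cc(OC)cc(OC)c2/C=C/C(=O)NC(C)C)cc1` has not yet been measured. It differs from compound 1 by a single change: methyl in place of hydrogen on a saturated chain carbon bound to an amide-type nitrogen and a saturated chain carbon. The ethyl of compound 1 becomes an isopropyl.

Among the compounds with values here, the steps that bear on this are those already seen at the same position. Going from compound 1 to compound 2 changes the group on the saturated chain carbon bound to the amide-type nitrogen, and going from compound 1 to compound 3 replaces the whole substituent on that nitrogen; neither moved the number beyond the scatter. A small added methyl at the same place is therefore expected to leave the number where it is. The estimate for compound 4 is 7000 nM, between 3500 nM and 14000 nM, which means an expected step of a 1.0-fold higher number from compound 1 to compound 4 (0.00 log units; within the scatter).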

Compound 4, half-maximal inhibitory concentration: 4020 nM
The estimate for compound 4 lay 1.7-fold (0.24 log units) above the measured number; the range from low to high includes it.
By their numbers in this assay, from the lowest: compounds 4, 1, 3 and 2 (each within the scatter of the next, the first and the last beyond it).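

In this assay, within the data shown here, the group on the amide-type nitrogen had so far produced no step beyond the scatter, and isopropyl is the first to do so, with a 2.0-fold lower number from compound 3 to compound 4 (0.31 log units; beyond the scatter) and a 2.1-fold lower number from compound 2 to compound 4 (0.31 log units; beyond the scatter), both modest. Against the ethyl of compound 1, the added methyl stays inside the scatter, with a 1.7-fold lower number from compound 1 to compound 4 (0.24 log units; within the scatter), so compound 4 and compound 1 cannot be ordered and neither stands out as the strongest of the four. The position therefore tolerates ethyl, propargyl, 3,4,5-trimethoxyphenyl and isopropyl with only a modest spread, and only isopropyl is separated from any other group, namely propargyl and 3,4,5-trimethoxyphenyl. Nothing given here accounts for these steps.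

The compounds shown leave open whether a further methyl on the same saturated chain carbon, giving a tert-butyl, would separate itself from the ethyl of compound 1 beyond the scatter. They also leave open what a cyclopropyl, a longer chain such as n-butyl, or a chain ending in an amine or a carboxylic acid would do on this nitrogen.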